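Ethoxy to propoxy: the step from compound 2 to compound 3

The compounds below may be only part of what the source reports. "The series", "measured", "known", "first", "only" and "open" are said of these compounds alone.

Two compounds of the series have numbers in an assay on HL-60 cells for inhibition of cytochrome P450 26A1 (Homo sapiens), read by HPLC, using microsomes and NADPH, with a stated time of 30 min; on this read-out lower numbers stand for stronger inhibition and higher numbers for weaker inhibition. Compound 1 `COC(=O)C(Cn1ccnc1)NC(=O)c1ccc(-c2ccccc2)cc1` gives 370 nM. Compound 2 `CCOC(=O)C(Cn1ccnc1)NC(=O)c1ccc(-c2ccccc2)cc1` gives 650 nM, the highest of the two numbers; its nearest neighbour is compound 1, and the step of a 1.8-fold higher number from compound 1 to compound 2 (0.24 log units; within the scatter) stays within the scatter. Compound 3 `CCCOC(=O)C(Cn1ccnc1)NC(=O)c1ccc(-c2ccccc2)cc1` is not yet measured. It differs from compound 2 by methyl in place of hydrogen on a saturated chain carbon, two bonds along the chain from an oxygen next to a carbonyl group. Going by the values given here, the only measured step that bears on this change is the like change from compound 1 to compound 2, which gave a 1.8-fold higher number from compound 1 to compound 2 (0.24 log units; within the scatter), within the scatter. On that basis no step beyond the scatter is expected in this assay from compound 2 to compound 3, at most a drift toward a higher number, that is an expected 1.4-fold higher number from compound 2 to compound 3 (0.14 log units; within the scatter). Compound 3 is therefore estimated at 900 nM, within a range from 400 nM to 2200 nM.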

Compound 3, half-maximal inhibitory concentration: 790 nM
Compound 3: the middle estimate sits 1.1-fold (0.06 log units) above what was measured; low and high end bracket the measured number.
By their numbers in this assay, from the lowest: compounds 1, 2 and 3 (each within the scatter of the next, the first and the last beyond it).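

In this assay, methyl at this position, two bonds along the chain from an oxygen next to a carbonyl group, gives a 1.2-fold higher number from compound 2 to compound 3 (0.08 log units; within the scatter), so ethoxy to propoxy brings no readable step. Ethyl in place of hydrogen on the saturated chain carbon bound to that oxygen gives a 2.1-fold higher number from compound 1 to compound 3 (0.33 log units; beyond the scatter), the first step in the series beyond the scatter, though only a modest one and visible only across both chain additions. Nothing measured here accounts for these numbers.

Still open, as far as these compounds go, is whether a longer chain or a branched one such as isopropyl would continue this modest rise or leave the number unchanged. Also open, from the compounds shown here alone, is how a carboxylic acid or an amide in place of the ester would read in this assay.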